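Ether analogues of an ester series in the cytotoxicity assay

The source may report more compounds than this note shows. Statements on the series, on what has been measured and on what is new or still open speak of the compounds shown alone.

Compound 1 `CCCCCC(=O)OCc1c(F)c(N)c2c(=O)cc(-c3ccc(N)c(F)c3)oc2c1F` gives 34000 nM in a functional assay on HeLa cells (Homo sapiens) for cytotoxicity, read by neutral red uptake, with a stated time of 3 days; a higher number here means a weaker inhibitor, a lower number a stronger inhibitor. Compound 2 `CN(C)CCC(=O)OCc1c(F)c(N)c2c(=O)cc(-c3ccc(N)c(F)c3)oc2c1F` gives 11000 nM in this assay, the step of a 3.1-fold lower number from compound 1 to compound 2 (0.49 log units; beyond the scatter) being the change (dimethylamino in place of propyl on a saturated chain carbon, two bonds along the chain from a carbonyl carbon). Compound 3 `CCCCCCOCc1c(F)c(N)c2c(=O)cc(-c3ccc(N)c(F)c3)oc2c1F` reports only a limit in this assay, > 100000 nM, and this limit is the one at which one of the three values sits (the limit of > 100000 nM in this assay, at which 1 of the 3 values shown sits). The cores of compound 3 and compound 1 differ by hexyl in place of pentylcarbonyl on an oxygen on a saturated carbon, so the steps of an at least 2.9-fold higher number from compound 1 to compound 3 (0.46 log units; beyond the scatter) and an at least 9.0-fold higher number from compound 2 to compound 3 (0.95 log units; beyond the scatter) both run to a limit. Compound 4 `CN(C)CCCOCc1c(F)c(N)c2c(=O)cc(-c3ccc(N)c(F)c3)oc2c1F` carries the change (dimethylamino in place of propyl on a saturated chain carbon, three bonds along the chain from an oxygen on a saturated carbon), the same kind of change as from compound 1 to compound 2 but on a saturated chain carbon three bonds along the chain from an oxygen on a saturated carbon rather than two bonds from a carbonyl carbon. From compound 3 the step of an at least 1.6-fold lower number from compound 3 to compound 4 (0.22 log units; that floor lies within the scatter) is expected, resting on the step of a 3.1-fold lower number from compound 1 to compound 2 (0.49 log units; beyond the scatter) applied from a limit. Compound 4 is estimated at 60000 nM, between 20000 nM and 200000 nM, with a limit likely.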

Compound 4, half-maximal inhibitory concentration: 12000 nM
Compound 4: the middle estimate sits 5.0-fold (0.70 log units) above what was measured; measured number outside the range, below it.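

In this assay, dimethylamino in place of propyl gives a lower number on both the core of compound 1 and the core of compound 3, but the size of the step does not carry over unchanged: the same change on two cores in this assay, a 3.1-fold lower number (0.49 log units; beyond the scatter) from compound 1 to compound 2 and an at least 8.3-fold lower number (0.92 log units; beyond the scatter) from compound 3 to compound 4, at least 2.6-fold (0.43 log units) apart, beyond the scatter of two such steps
The value of compound 3, > 100000 nM, is a limit, so the step of an at least 8.3-fold lower number from compound 3 to compound 4 (0.92 log units; beyond the scatter) gives only a floor for the size of the change on that core.
The other new steps are a 1.1-fold higher number from compound 2 to compound 4 (0.04 log units; within the scatter) and a 2.8-fold lower number from compound 1 to compound 4 (0.45 log units; beyond the scatter); two cores support no general rule for the series, and these values do not show why the step sizes differ.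

On these data alone, whether a morpholine or a carboxylic acid at the same chain end would give a similar step on both cores remains open. As far as these compounds go, a longer chain carrying the dimethylamino group also remains open.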